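The compounds below may be only part of what the source reports. "The series", "measured", "known", "first", "only" and "open" are said of these compounds alone.

Measured compounds:
compound 1, `CC(C)CCC(=O)N[C@@H](C(=O)N1CCC(c2ccc(Cl)cc2)CC1)C(C)C` — 26 nM
compound 2, `CC(C)C(NC(=O)c1ccccc1)C(=O)N1CCN(c2ccc(Cl)cc2)CC1` — 525 nM

In an assay on THP-1 cells for displacement of a labelled ligand from C-C chemokine receptor type 1 (Homo sapiens) (on this read-out higher numbers stand for weaker inhibition and lower numbers for stronger inhibition), compound 1 gives 26 nM, the lower of the two numbers reported. Compound 2 gives 525 nM, a markedly higher number, well beyond the scatter; since the two structures differ in several places at once, their values are compared only as they stand, with no single change counted between them.

Compound 3, `CC(C)CC(=O)N[C@@H](C(=O)N1CCC(c2ccc(Cl)cc2)CC1)C(C)C`, has not yet been measured in this assay. It differs from compound 1 in a single place: isopropyl in place of isobutyl on a saturated chain carbon bound to a carbonyl carbon. For the measured compounds named here, no measured pair isolates this change, so the size of the step rests on the closeness of the two structures alone. A shorter saturated chain of this kind is expected to move the number little, either within the scatter or modestly in the weaker direction.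

Compound 3 is expected to give about 40 nM, in a range from 15 nM to 120 nM. The expected step of a 1.5-fold higher number from compound 1 to compound 3 (0.19 log units; within the scatter) is small, at most slightly beyond the scatter.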

Compound 3, half-maximal inhibitory concentration: 32 nM
Compound 3: the middle estimate sits 1.3-fold (0.10 log units) above what was measured; the measured number falls inside the stated range.
By their numbers in this assay, from the lowest: compounds 1 and 3 (each within the scatter of the next); then compound 2.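

In this assay, isopropyl in place of isobutyl on a saturated chain carbon bound to a carbonyl carbon gives a 1.2-fold higher number from compound 1 to compound 3 (0.09 log units; within the scatter), a step within the scatter. For the compounds shown here, this is the first pair that isolates a single change, and it shows that at this place the two groups cannot be told apart on this read-out. The data offer no measured explanation for this result.

Still open, going by these compounds, is whether a much longer chain, a cyclohexyl ring or a basic amine at this place would leave the number as undisturbed as isopropyl does. Also open, on these data alone, is whether the same exchange would read alike on a different core, since this single pair speaks only for the core of compound 1.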